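Halogen exchange on the phenyl substituent of compound 2

The source may hold more compounds than are shown below. What is called first, only, known or untested is meant among the compounds shown, and "the series" means these compounds.

Compound 1 `C=C1C[C@]23C[C@@]1(O)CC[C@H]2c1cc(Br)c(O)c(C)c1[C@@H]3Cn1cc(-c2ccccc2)nn1`: in a functional assay on MCF7 cells (Homo sapiens) for cytotoxicity, read by MTT assay, with a stated time of 4 days (on this read-out lower numbers stand for stronger inhibition and higher numbers for weaker inhibition), compound 1 gives only the limit > 20000 nM.
Compound 2 `C=C1C[C@]23C[C@@]1(O)CC[C@H]2c1cc(Br)c(O)c(C)c1[C@@H]3Cn1cc(-c2ccc(Cl)cc2)nn1`: in this assay compound 2 gives 10200 nM.

Compound 2 holds the only number shown; the other value is a limit. For the measured compounds named here, the one measured step, an at least 1.9-fold lower number from compound 1 to compound 2 (0.29 log units; that floor lies within the scatter), touches the limit (the limit of > 20000 nM in this assay, at which 1 of the 2 values shown sits), so its size is a floor within the scatter. Compound 3 `C=C1C[C@]23C[C@@]1(O)CC[C@H]2c1cc(Br)c(O)c(C)c1[C@@H]3Cn1cc(-c2ccc(F)cc2)nn1` differs from compound 2 by fluoro in place of chloro on an aromatic carbon. Fluoro stands between hydrogen and chloro, so in this assay no step beyond the scatter is expected, leaning weaker. Compound 3 is estimated at 15000 nM, range 7000 nM to 30000 nM, a step of a 1.5-fold higher number from compound 2 to compound 3 (0.17 log units; within the scatter).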

Compound 3, half-maximal inhibitory concentration: 19200 nM
Beside the measured number, compound 3's estimate is 1.3-fold (0.11 log units) below it; measured number inside the range.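

In this assay, fluoro in place of chloro on this aromatic carbon, para to a large group, gives a 1.9-fold higher number from compound 2 to compound 3 (0.27 log units; within the scatter), so 4-chlorophenyl and 4-fluorophenyl are not told apart here. Unlike the earlier step, this one rests on two measured numbers rather than a limit. The step of an at least 1.0-fold lower number from compound 1 to compound 3 (0.01 log units; that floor lies within the scatter) gives only a floor, set by a limit: the limit of > 20000 nM in this assay, at which 1 of the 3 values shown sits.

On these data alone, whether an amine, a carboxylic acid or a methoxy group on this aromatic carbon would move the number beyond the scatter stays open.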